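Shortening the side chain on a nucleoside transporter inhibitor

The source may hold more compounds than are shown below. What is called first, only, known or untested is meant among the compounds shown, and "the series" means these compounds.

Compound 1 `Nc1ncnc2c1nc(NCCCc1ccccc1)n2[C@@H]1O[C@H](CO)[C@@H](O)[C@H]1O` is one of three adenosine-like compounds examined here in an assay on COS-7 cells for inhibition of sodium/nucleoside cotransporter 2 (Homo sapiens), read by scintillation counting, in the presence of a further agent that is not named here (a higher number here means a weaker inhibitor, a lower number a stronger inhibitor), where compound 1 gives 536000 nM. Of the two numbers that were reached, this is the higher one. Compound 2 `Nc1ncnc2c1nc(NCc1ccc(-c3ccccc3)cc1)n2[C@@H]1O[C@H](CO)[C@@H](O)[C@H]1O`, which carries a biphenylmethyl group on the same nitrogen, gives 640 nM in this assay, a far stronger inhibition that lies well beyond the usual scatter. Compound 3 `CNC(=O)OC[C@H]1O[C@@H](n2cnc3c(N)ncnc32)[C@H](O)[C@@H]1O`, which lacks any substituent on that nitrogen and instead bears a carbamate on the sugar, reaches only the limit of > 100000 nM in this assay; this is a limit of the assay and not a number, and it is the case described by the limit of > 100000 nM in this assay, at which 1 of the 3 values shown sits.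

The step to compound 4 `Cc1cccc(CNc2nc3c(N)ncnc3n2[C@@H]2O[C@H](CO)[C@@H](O)[C@H]2O)c1` shortens the chain on that nitrogen: 3-methylphenyl in place of phenethyl on a saturated chain carbon bound to a nitrogen on an aromatic ring. Compound 2 shows that a single-carbon link between the nitrogen and an aromatic ring can sit with a value of 640 nM, so compound 4 is expected to improve on compound 1 by a step of a 27-fold lower number from compound 1 to compound 4 (1.43 log units; beyond the scatter), in the direction of stronger inhibition. The expected value for compound 4 in this assay is 20000 nM, with a range from 2000 nM to 200000 nM.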

Compound 4, half-maximal inhibitory concentration: 19000 nM
The estimate for compound 4 lay 1.1-fold (0.02 log units) above the measured number; the range from low to high includes it.
By their numbers in this assay, from the lowest: compound 2; then compound 4; then compound 1.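

In this assay, replacing the 3-phenylpropyl group with 3-methylbenzyl gives a 28-fold lower number from compound 1 to compound 4 (1.45 log units; beyond the scatter). This puts a size on how much inhibition can shift at this position, even though the group that leaves and the group that enters each hold one six-membered aromatic ring of carbon only and neither has any hydrogen-bond donors or acceptors. Nothing measured in this set accounts for the size of the step, so the numbers record the change without explaining it.

The swap alters two things at once, the chain and the methyl on the ring, so the compounds shown cannot say how much of the step belongs to each; a plain benzyl group at this place would be the direct test of that. Also open, from the compounds shown here alone, is whether the position accepts anything other than carbon in this group, such as an amine or a carboxylic acid on the ring in place of the methyl, and how inhibition would respond to either.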